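From benzyl to 2-fluorobenzyl in compound 3

This account rests on a few compounds, and the source may have more. Where it says the series, first, only, none or still open, it means among the compounds named here.

- compound 1 `O=[N+]([O-])c1cc(C(F)(F)F)cc([N+](=O)[O-])c1Oc1ccc(Cl)cc1/C=N\OCc1ccccc1F` gives 1110 nM
- compound 2 `O=[N+]([O-])c1cc(C(F)(F)F)cc([N+](=O)[O-])c1Oc1c(Cl)cc(Cl)cc1/C=N\OCc1ccccc1` gives 1210 nM

Both compounds were tested in a functional assay on MCF7 cells (Homo sapiens) for antiproliferative activity, read by MTT assay, with a stated time of 48 h; on this read-out lower numbers stand for stronger inhibition and higher numbers for weaker inhibition. Going by the values given here, compound 2, at 1210 nM, stands within the usual scatter of compound 1, the only other measured compound, so the two cannot be ranked.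

Compound 3 `O=[N+]([O-])c1cc(C(F)(F)F)cc([N+](=O)[O-])c1Oc1c(Cl)cc(Cl)cc1/C=N\OCc1ccccc1F` has not yet been measured. It derives from compound 2 by placing fluoro in place of hydrogen on an aromatic carbon, ortho to a large group, which turns benzyl into 2-fluorobenzyl: fluoro in place of hydrogen on an aromatic carbon. Among the compounds with values here, no measured pair shows this change alone. Compound 1, which also carries 2-fluorobenzyl, gives 1110 nM, so little movement is expected in this assay. The estimated change is a 1.2-fold lower number from compound 2 to compound 3 (0.06 log units; within the scatter), which would not go beyond the scatter. For compound 3 the expected value is 1050 nM, with an estimated range from 480 nM to 2300 nM.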

Compound 3, half-maximal inhibitory concentration: 800 nM
Compound 3: middle estimate off by 1.3-fold (0.12 log units), on the high side, within the range that was stated.
By their numbers in this assay, from the lowest: compounds 3, 1 and 2 (each within the scatter of the next).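

In this assay, going by these compounds alone, the first direct pair for fluoro in place of hydrogen on an aromatic carbon, which turns benzyl into 2-fluorobenzyl, gives a step that stays within the scatter (a 1.5-fold lower number from compound 2 to compound 3 (0.18 log units; within the scatter)). The second pair, which adds a chloro where a hydrogen stood, also stays within the scatter (a 1.4-fold lower number from compound 1 to compound 3 (0.14 log units; within the scatter)), so neither single change separates compound 3 from its neighbour in this assay. No measurement at hand bears on why these steps have this size.

The compounds shown leave open whether any other group at this place would move the number beyond the scatter, since only hydrogen and fluoro appear there. A methoxy group, an amine or a carboxylic acid in that place remains an open question.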